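Cyano for trifluoromethyl on a sulfonamide-bearing ring

This account rests on a few compounds, and the source may have more. Where it says the series, first, only, none or still open, it means among the compounds named here.

Of the compounds shown here, two sharing one core have been measured in a functional assay on NCI-H146 cells (Homo sapiens) for cytotoxicity, with a stated time of 48 h, in the presence of a further agent that is not named here; a higher number here means that more compound is needed for the effect, a lower number that less compound is needed. Compound 1, `CN(C)CC[C@H](CSc1ccccc1)Nc1ccc(S(=O)(=O)NC(=O)c2ccc(N3CCN(Cc4ccccc4-c4ccc(Cl)cc4)CC3)cc2)cc1C(F)(F)F`, gives 2460 nM in this assay. Compound 2, `CN(C)CC[C@H](CSc1ccccc1)Nc1ccc(S(=O)(=O)NC(=O)c2ccc(N3CCN(C/C4=C(\c5ccc(Cl)cc5)CCCCCC4)CC3)cc2)cc1[N+](=O)[O-]`, gives 200 nM in this assay. Of these two numbers, compound 1 carries the higher one, and the gap between compound 1 and compound 2 lies beyond the usual scatter of repeated measurements; compound 2 differs from compound 1 in more than one place, so the two values show only where each stands, not what any single change does.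

Compound 3, `CN(C)CC[C@H](CSc1ccccc1)Nc1ccc(S(=O)(=O)NC(=O)c2ccc(N3CCN(Cc4ccccc4-c4ccc(Cl)cc4)CC3)cc2)cc1C#N`, has not yet been measured. It differs from compound 1 in one place: cyano in place of trifluoromethyl on an aromatic carbon. Among the measured compounds shown here, no measured pair here isolates this change, so its effect is not known from these data. The expectation is a step of modest size in this assay, towards a somewhat lower number, though a step of no more than the scatter would not be surprising. Compound 3 is therefore expected to give about 1500 nM in this assay, within a range from 500 nM to 5000 nM, which corresponds to an expected step of a 1.6-fold lower number from compound 1 to compound 3 (0.21 log units; within the scatter).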

Compound 3, half-maximal effective concentration: 1930 nM
The estimate for compound 3 lay 1.3-fold (0.11 log units) below the measured number, within the range that was stated.
By their numbers in this assay, from the lowest: compound 2; then compounds 3 and 1 (each within the scatter of the next).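

In this assay, among the compounds shown here, cyano in place of trifluoromethyl on this aromatic carbon gives a 1.3-fold lower number from compound 1 to compound 3 (0.11 log units; within the scatter), which makes this the first comparison here that isolates a single change. The earlier pair, compound 1 and compound 2, differed in more than one place and could not show what this position does; now compound 1 and compound 3 show that, in this assay and on this core, the two groups cannot be told apart, even though cyano has fewer heavy atoms than trifluoromethyl and, unlike it, counts as a hydrogen-bond acceptor. Nothing available explains why the swap leaves the number within the scatter.

Compound 2 carries a nitro group on the corresponding aromatic carbon, but its other differences from compound 1 mean that its much lower number cannot be credited to nitro, so a nitro group on the core of compound 1 remains an open comparison. Also open, going by these compounds, is what an amine, a carboxylic acid or a longer chain at this position would do, and whether the match between cyano and trifluoromethyl would hold on the core of compound 2.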